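Replacing the methyl of compound 3 with pyridin-2-yl

This account rests on a few compounds, and the source may have more. Where it says the series, first, only, none or still open, it means among the compounds named here.

Three compounds sharing one core have numbers in a functional assay on DU-145 cells (Homo sapiens) for antiproliferative activity, read by MTT assay; on this read-out higher numbers stand for weaker inhibition and lower numbers for stronger inhibition. Compound 1 `Fc1ccc(N2CCN(c3nc(-n4ccc5ccccc54)c4ccccc4n3)CC2)cc1` gives 50 ug/mL. Compound 2 `c1ccc(N2CCN(c3nc(-n4ccc5ccccc54)c4ccccc4n3)CC2)cc1` gives 50 ug/mL. Compound 3 `CN1CCN(c2nc(-n3ccc4ccccc43)c3ccccc3n2)CC1` gives 20.8 ug/mL, the lowest number of the three and the strongest inhibition in this small set.

Compound 4 `c1ccc(N2CCN(c3nc(-n4ccc5ccccc54)c4ccccc4n3)CC2)nc1` has no number yet. Its difference from compound 3 is pyridin-2-yl in place of methyl on an amine nitrogen in a ring: an aromatic ring returns to the amine nitrogen in place of methyl.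

The closest guides are the two steps that exchange an aromatic ring for methyl at this nitrogen: a 2.4-fold lower number from compound 2 to compound 3 (0.38 log units; beyond the scatter) and a 2.4-fold lower number from compound 1 to compound 3 (0.38 log units; beyond the scatter). Both are modest, and the change to compound 4 runs in the opposite direction. The remaining step, no change at the digits printed from compound 1 to compound 2 (within the scatter), shows no shift when the fluoro is removed from the aromatic ring. Among the compounds with values here, no measured compound carries a ring nitrogen in that aromatic ring, so pyridin-2-yl itself remains untested.

A step of similar modest size toward weaker inhibition is therefore expected, and the estimated step is a 2.2-fold higher number from compound 3 to compound 4 (0.34 log units; beyond the scatter). For compound 4 the estimated value in this assay is 45 ug/mL, with an expected range of 25 ug/mL to 70 ug/mL.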

Compound 4, half-maximal inhibitory concentration: 50 ug/mL
Beside the measured number, compound 4's estimate is 1.1-fold (0.05 log units) below it, and the stated range covers the measured number.
By their numbers in this assay, from the lowest: compound 3; then compounds 1, 2 and 4 (each within the scatter of the next).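

In this assay, pyridin-2-yl in place of methyl on the amine nitrogen in the ring gives a 2.4-fold higher number from compound 3 to compound 4 (0.38 log units; beyond the scatter), so a third aromatic ring at this position falls with phenyl and 4-fluorophenyl rather than with methyl. Among the aromatic groups, the ring nitrogen and its added hydrogen-bond acceptor leave the read-out flat, with no change at the digits printed from compound 2 to compound 4 (within the scatter) and no change at the digits printed from compound 1 to compound 4 (within the scatter), so the two changes within the aromatic ring, removing fluoro and introducing a ring nitrogen, show no effect here, and across these three aromatic groups only their contrast with methyl registers. No measurement at hand accounts for this difference between methyl and the aromatic rings.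

Methyl remains the only non-aromatic group shown at this nitrogen, so it stays open whether the lower number of compound 3 belongs to methyl alone or extends to ethyl, isopropyl or a plain hydrogen on the nitrogen. Also open, from the compounds shown here alone, is how a benzyl group or a 2-hydroxyethyl chain would read at this position, since either would show whether a ring attached through a carbon or a longer chain moves the number away from the aromatic compounds.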